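The source may hold more compounds than are shown below. What is called first, only, known or untested is meant among the compounds shown, and "the series" means these compounds.

In a physicochemical assay for solubility, read by HPLC (on this read-out higher numbers stand for higher solubility and lower numbers for lower solubility), compound 1 `COc1ccc(NC[C@H](O)COc2ccc(N3C[C@H](CNC(C)=O)OC3=O)cc2F)cc1` gives 56000 nM, within the scatter of compound 3 `CC(=O)NC[C@H]1CN(c2ccc(OC[C@H](O)CNc3ccc(C#N)cc3)c(F)c2)C(=O)O1` at 69000 nM, while compound 2 `COc1ccc(NC[C@@H](O)COc2ccc(N3C[C@H](CNC(C)=O)OC3=O)cc2F)cc1` gives 1300 nM. Compound 4 `CC(=O)NC[C@H]1CN(c2ccc(OC[C@@H](O)CNc3ccccn3)c(F)c2)C(=O)O1` has pyridin-2-yl in place of 4-methoxyphenyl on an amine nitrogen and keeps the configuration as drawn in compound 1. The large 43-fold lower number from compound 1 to compound 2 (1.63 log units; beyond the scatter) arose due to the fact that compounds 1 and 2 differ only in the configuration as drawn, so that step does not carry over here. For the measured compounds named here, the large 53-fold higher number from compound 2 to compound 3 (1.72 log units; beyond the scatter) is the nearest precedent, but it involved cyano and the other configuration. The expectation therefore stays anchored on compound 1 at 56000 nM. In this assay the estimated step is a 1.3-fold higher number from compound 1 to compound 4 (0.10 log units; within the scatter), with none expected beyond the scatter. For compound 4 the expected value is 70000 nM, with an estimated range from 20000 nM to 250000 nM.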

Compound 4, solubility: 22200000 nM
Beside the measured number, compound 4's estimate is 320-fold (2.50 log units) below it; the measured number lies above the stated range.
By their numbers in this assay, from the lowest: compound 2; then compounds 1 and 3 (each within the scatter of the next); then compound 4.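

Replacing 4-methoxyphenyl with pyridin-2-yl on the amine nitrogen gives a 400-fold higher number from compound 1 to compound 4 (2.60 log units; beyond the scatter) in this assay, with the configuration as drawn in compound 1 kept. The numbers at this position therefore reach well beyond the range spanned by compounds 1, 2 and 3. Nothing available bears on why this step is so large.

Compound 4 both introduces the ring nitrogen and loses the methoxy group, so a plain phenyl on the amine nitrogen would be needed to separate the two. From the compounds shown here alone, whether pyridin-2-yl behaves alike in the other configuration, that of compound 2, remains open.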